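A few compounds are considered here, and "the series" means these few. Any claim that something is new, unique, unknown or untested is made for them only; others in the source may bear on it.

In a functional assay on MCF7 cells (Homo sapiens) for antiproliferative activity, read by MTT assay, with a stated time of 72 h (a higher number here means a weaker inhibitor, a lower number a stronger inhibitor), compound 1 `COc1ccc(/C=C2/CN(C)/C(=N/c3ccc(C(C)(C)C)cc3)S2)cc1` gives 28700 nM and compound 2 `COc1ccc(/C=C2\S/C(=N\c3ccc(Cl)cc3)N(C)C2=O)cc1` gives 39300 nM, two values within the scatter of each other. For compound 3 `C=C1CN(C)/C(=N/c2ccccc2)S1` the result is only a limit, > 100000 nM. Compound 4 `COc1ccc(/C=C2/CN(C)/C(=N/c3ccc(OC)cc3)S2)cc1` keeps the core of compound 1 and differs from it in one place: methoxy in place of tert-butyl on an aromatic carbon. Methoxy stands in place of tert-butyl on an aromatic carbon, para to a large group. Among the measured compounds shown here, no measured pair isolates this exchange, so the expectation in this assay rests on the standing of compound 1 alone. The estimated 1.2-fold higher number from compound 1 to compound 4 (0.09 log units; within the scatter) is not expected to go beyond the scatter. For compound 4 the expected value is 35000 nM, with an estimated range of 15000 nM to 85000 nM.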

Compound 4, half-maximal inhibitory concentration: 8700 nM
Beside the measured number, compound 4's estimate is 4.0-fold (0.60 log units) above it, outside the stated range (below it).
By their numbers in this assay, from the lowest: compound 4; then compounds 1 and 2 (each within the scatter of the next). At a limit, above all of these: compound 3.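

In this assay, the aromatic carbon para to a large group proves sensitive to substitution: methoxy in place of tert-butyl gives a 3.3-fold lower number from compound 1 to compound 4 (0.52 log units; beyond the scatter). The tert-butyl group is therefore not required at this position to retain the activity of the shared core, and the smaller methoxy group is tolerated there. No measurement shown bears on why this exchange lowers the number.

With only these two groups compared at this position, the roles of the oxygen and of group size cannot be separated. From the compounds shown here alone, how an amine, a carboxylic acid or a longer chain such as ethoxy would fare there remains open.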